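The source may hold more compounds than are shown below. What is called first, only, known or untested is meant among the compounds shown, and "the series" means these compounds.

Working notes on the series.

Among the measured compounds shown here, compound 1 `CC(C)(C)c1ccc(C(=O)N2CCC3(CC2)C(=O)N(CC(=O)NCCC(=O)O)CN3c2ccccc2)cc1` gives 11400 nM in an assay on HEK293 cells for displacement of a labelled ligand from NPC1-like intracellular cholesterol transporter 1 (Homo sapiens) (on this read-out higher numbers stand for weaker inhibition and lower numbers for stronger inhibition), the highest of the three numbers measured so far. Compound 2 `O=C(CN1CN(c2ccccc2)C2(CCN(C(=O)c3ccc(C4CCCCC4)cc3)CC2)C1=O)N1CCCCC1` gives 1100 nM in this assay, and compound 3 `NC(=O)C1CCCN(C(=O)CN2CN(c3ccccc3)C3(CCN(C(=O)c4ccc(C5CCCCC5)cc4)CC3)C2=O)C1` gives 3100 nM in this assay. Compound 1 therefore sits furthest from compound 2 and nearest to compound 3, both gaps beyond the scatter.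

The next step leads to compound 4 `CC(C)(C)c1ccc(C(=O)N2CCC3(CC2)C(=O)N(CC(=O)NCN)CN3c2ccccc2)cc1`, which differs from compound 1 in one place: amino in place of carboxymethyl on a saturated chain carbon bound to an amide-type nitrogen. Carboxymethyl leaves and amino enters on the saturated chain carbon bound to an amide-type nitrogen.

For the measured compounds named here, the only measured step, a 2.8-fold higher number from compound 2 to compound 3 (0.45 log units; beyond the scatter), concerns a carbamoyl in place of hydrogen on a saturated ring carbon and on a different pair of compounds, so it does not bear on this change directly. Going by the values given here, compounds 1 and 2 differ in several places at once, and no single-point step connects them; their two values show only that the acid-bearing compound 1 sits far higher. For compound 4 a modest lowering is expected, a 1.9-fold lower number from compound 1 to compound 4 (0.28 log units; within the scatter), with wide uncertainty in this assay. The estimate for compound 4 in this assay is 6000 nM, within 2000 nM to 20000 nM.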

Compound 4, half-maximal inhibitory concentration: 26500 nM
Beside the measured number, compound 4's estimate is 4.4-fold (0.65 log units) below it, and the stated range ends below it.
By their numbers in this assay, from the lowest: compound 2; then compound 3; then compound 1; then compound 4.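

Amino in place of carboxymethyl on the saturated chain carbon bound to an amide-type nitrogen brings a 2.3-fold higher number from compound 1 to compound 4 (0.37 log units; beyond the scatter) in this assay, the first step read at this position. Within this pair, removing the carboxylic acid does not lower the number: the (aminomethyl)carbamoyl compound stands above the (2-carboxyethyl)carbamoyl compound, and the step lies beyond the scatter. Nothing available accounts for this step.

In this step, chain length and end group change together, so the compounds shown leave open whether a longer chain ending in an amine, such as 2-aminoethyl, would read nearer compound 1 or compound 4. Also open, from the compounds shown here alone, is how a chain of the same length ending in a hydroxyl would read at this position.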